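A methyl for fluoro swap carried to a second core

The compounds below may be only part of what the source reports. "The series", "measured", "known", "first", "only" and "open" are said of these compounds alone.

Compound 1 `N#Cc1ccc(NC(=O)c2ccc3cccnc3c2O)c(F)c1` and compound 2 `Cc1cc(C#N)ccc1NC(=O)c1ccc2cccnc2c1O` share one core. In a functional assay on HL-60 cells (Homo sapiens) for cytotoxicity, read by luminescence and CellTiter-Glo, with a stated time of 3 days (a higher number here means a weaker inhibitor, a lower number a stronger inhibitor), compound 1 gives 730 nM, and compound 2 gives 710 nM. The change between them, (methyl in place of fluoro on an aromatic carbon), made a 1.0-fold lower number from compound 1 to compound 2 (0.01 log units; within the scatter). Compound 3 `N#Cc1ccc(NC(=O)c2c(O)cccc2F)cc1` rests on a different core; how the two cores differ is not broken down here. In this assay compound 3 reaches only a limit, > 10000 nM, which is the limit of > 10000 nM in this assay, at which 1 of the 3 values shown sits. Compound 4 `Cc1cccc(O)c1C(=O)Nc1ccc(C#N)cc1` carries the same kind of change, (methyl in place of fluoro on an aromatic carbon); here the place is meta to a hydroxy group (1 heavy atom), whereas in compound 2 it is meta to a cyano group (2 heavy atoms). Because the measured step of a 1.0-fold lower number from compound 1 to compound 2 (0.01 log units; within the scatter) lay within the scatter, the expected step is a step that the limit leaves unreadable from compound 3 to compound 4. Compound 4 is expected to give 15000 nM, most likely again only a limit, between 5000 nM and 50000 nM.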

Compound 4, half-maximal inhibitory concentration: 6860 nM
Compound 4: middle estimate off by 2.2-fold (0.34 log units), on the high side, within the range that was stated.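

On the core of compound 3, the methyl for fluoro swap in this assay gives an at least 1.4-fold lower number from compound 3 to compound 4 (0.16 log units; that floor lies within the scatter), and that figure is only a floor. Compound 3 stands at a limit of the assay, > 10000 nM. Neither core shows a step beyond the scatter so far, but this does not establish that the change carries over equally from one core to the other, nor that it fails to: the same change on two cores in this assay, a 1.0-fold lower number (0.01 log units; within the scatter) from compound 1 to compound 2 and an at least 1.4-fold lower number (0.16 log units; that floor lies within the scatter) from compound 3 to compound 4; the limit leaves it open whether they differ

The compounds shown leave open how an amine, a methoxy group or a chlorine would compare with methyl and fluoro at these places. They also leave open the full size of the step on the core of compound 3, and whether a third core would follow the same course.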